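The source may report more compounds than this note shows. Statements on the series, on what has been measured and on what is new or still open speak of the compounds shown alone.

Measured so far in a functional assay on HT-29 cells (Homo sapiens) for cytotoxicity, read by MTT assay, with a stated time of 72 h; on this read-out lower numbers stand for stronger inhibition and higher numbers for weaker inhibition:
compound 1 `Cn1c(=O)c(C(=O)Nc2ccc(Oc3ccncc3-c3cccnc3)c(F)c2)nn(-c2ccc(Cl)cc2)c1=O`, 440 nM;
compound 2 `Cn1c(=O)c(C(=O)Nc2ccc(Oc3ccncc3-c3cccnc3)c(F)c2)nn(-c2cccc(C(F)(F)F)c2)c1=O`, 510 nM;
compound 3 `Cn1c(=O)c(C(=O)Nc2ccc(Oc3ccncc3-c3cccnc3)c(F)c2)nn(-c2c(Cl)cccc2Cl)c1=O`, 780 nM.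

Compound 3 sits apart from compound 1 by a 1.8-fold higher number from compound 1 to compound 3 (0.25 log units; within the scatter) and from compound 2 by a 1.5-fold higher number from compound 2 to compound 3 (0.18 log units; within the scatter), both within the scatter, as is a 1.2-fold higher number from compound 1 to compound 2 (0.06 log units; within the scatter). Compound 4 `Cn1c(=O)c(C(=O)Nc2ccc(Oc3ccncc3-c3cccnc3)c(F)c2)nn(-c2ccc(F)c(Cl)c2)c1=O` differs from compound 3 by 3-chloro-4-fluorophenyl in place of 2,6-dichlorophenyl on an aromatic nitrogen. Every measured step exchanges the aryl group on that same aromatic nitrogen, and none moves this assay beyond the scatter, so for this further exchange no shift beyond the scatter is expected in either direction. Compound 4 is therefore estimated at 600 nM, within 250 nM to 1500 nM. That estimate means a step of a 1.3-fold lower number from compound 3 to compound 4 (0.11 log units; within the scatter), expected to stay within the scatter.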

Compound 4, half-maximal inhibitory concentration: 4780 nM
Beside the measured number, compound 4's estimate is 8.0-fold (0.90 log units) below it, outside the stated range (above it).
By their numbers in this assay, from the lowest: compounds 1, 2 and 3 (each within the scatter of the next); then compound 4.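

In this assay the aryl group on this aromatic nitrogen can move the number beyond the scatter: 3-chloro-4-fluorophenyl gives a 6.1-fold higher number from compound 3 to compound 4 (0.79 log units; beyond the scatter) and a 9.4-fold higher number from compound 2 to compound 4 (0.97 log units; beyond the scatter) and also an 11-fold higher number from compound 1 to compound 4 (1.04 log units; beyond the scatter). The position is therefore not indifferent to aryl exchange, even though 4-chlorophenyl, 3-(trifluoromethyl)phenyl and 2,6-dichlorophenyl stay within the scatter of one another. Nothing available here accounts for this step. On these data alone, it remains open whether the step follows the fluorine or the chlorine of the new group, and how an aryl group bearing an amine or a carboxylic acid would read.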